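This account rests on a few compounds, and the source may have more. Where it says the series, first, only, none or still open, it means among the compounds named here.

Notes on the series. Compound 1 `OC[C@H]1O[C@@H](n2cnc3c(NCc4cccc(F)c4)ncnc32)[C@H](O)[C@@H]1O` gives 7600 nM in a functional assay on K562 cells (Homo sapiens) for antiproliferative activity, with a stated time of 72 h; a lower number here means a stronger inhibitor, a higher number a weaker inhibitor. Compound 2 `COc1ccccc1CNc1ncnc2c1ncn2[C@@H]1O[C@H](CO)[C@@H](O)[C@H]1O` gives 89000 nM in this assay, the highest number of the three measured, and compound 3 `OC[C@H]1O[C@@H](n2cnc3c(NCc4cccc(O)c4O)ncnc32)[C@H](O)[C@@H]1O` gives 25800 nM. Relative to compound 2, the nearest measured value is that of compound 3, the furthest that of compound 1. Every measured step swaps the whole aryl group on a saturated chain carbon bound to a nitrogen on an aromatic ring: a 12-fold higher number from compound 1 to compound 2 (1.07 log units; beyond the scatter); a 3.4-fold higher number from compound 1 to compound 3 (0.53 log units; beyond the scatter); a 3.4-fold lower number from compound 2 to compound 3 (0.54 log units; beyond the scatter).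

Compound 4 `OC[C@H]1O[C@@H](n2cnc3c(NCc4ccccc4OC(F)F)ncnc32)[C@H](O)[C@@H]1O` differs from compound 2 in one place: difluoromethyl in place of methyl on an oxygen on an aromatic ring. Cut one bond further out, this reads methoxy to difluoromethoxy, so the 2-methoxyphenyl of compound 2 becomes 2-(difluoromethoxy)phenyl. Within the data shown here, no measured step bears on it directly: each step exchanges the aryl group as a whole, and none keeps the aromatic ring and alters only what sits on its oxygen. The steps show that the number moves strongly with the aryl group, but they give no direction for a change within the 2-methoxyphenyl itself. The expected step from compound 2 to compound 4 is therefore none beyond the scatter, a 1.5-fold lower number from compound 2 to compound 4 (0.17 log units; within the scatter), with a wide range to allow for movement either way. Compound 4 is estimated at 60000 nM in this assay, with a range from 15000 nM to 200000 nM.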

Compound 4, half-maximal inhibitory concentration: > 166000 nM
Compound 4: no number, only a limit; the forecaster's own chance of this, stated with the estimate: 10%; middle value at least 2.7-fold (0.44 log units) from the limit.
By their numbers in this assay, from the lowest: compound 1; then compound 3; then compound 2. At a limit, above all of these: compound 4.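

Compound 4 gives only a limit in this assay: the limit of > 166000 nM in this assay, at which 1 of the 4 values shown sits. At this oxygen on an aromatic ring, difluoromethyl in place of methyl gives an at least 1.8-fold higher number from compound 2 to compound 4 (0.27 log units; that floor lies within the scatter), so the change shows no sign of lowering the number, though that floor alone does not separate the two compounds. The 2-(difluoromethoxy)phenyl group also stays far from the other two aryl groups, with an at least 6.4-fold higher number from compound 3 to compound 4 (0.80 log units; beyond the scatter) and an at least 21-fold higher number from compound 1 to compound 4 (1.33 log units; beyond the scatter), so compound 4 joins compound 2 at the high end of the series, a change at the oxygen alone having given no way back towards the lower numbers of compound 1 and compound 3.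

As far as these compounds go, while only a limit stands, it remains open how large the step to compound 4 really is, and whether it lies beyond the scatter. Also open, from the compounds shown here alone, is how an ethyl or a trifluoromethyl on this oxygen, or an amine in place of the whole methoxy group, would read in this assay.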